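The source may report more compounds than this note shows. Statements on the series, on what has been measured and on what is new or still open speak of the compounds shown alone.

Compound 1 `CC(C)C[C@H](N)c1cc(C(F)(F)F)ccc1N1CCN(C(=O)COc2cccc(Cl)c2Cl)CC1` and compound 2 `Cc1ccc(OCC(=O)N2CCN(c3ccc(C(F)(F)F)cc3[C@@H](N)CC(C)C)CC2)c(C)c1` share one core. In an assay on HEK293 cells for displacement of a labelled ligand from Melanocortin receptor 4 (Homo sapiens) (a lower number here means a stronger inhibitor, a higher number a weaker inhibitor), compound 1 gives 2500 nM, and compound 2 gives 4000 nM, the higher of the two numbers, though the step of a 1.6-fold higher number from compound 1 to compound 2 (0.20 log units; within the scatter) lies within the scatter. Compound 3 `Cc1cc(CC(C)C(=O)N2CCN(c3ccc(C(F)(F)F)cc3[C@@H](N)CC(C)C)CC2)ccc1Cl` carries 1-(4-chloro-3-methylbenzyl)ethyl in place of (2,4-dimethylphenoxy)methyl on a carbonyl carbon. For the measured compounds named here, no measured step touches this kind of change; the only step in hand, a 1.6-fold higher number from compound 1 to compound 2 (0.20 log units; within the scatter), is small and concerns the aryl group alone, so no step beyond the scatter is expected in this assay. Compound 3 is therefore estimated at 4000 nM, in a range from 1200 nM to 13000 nM, which is an expected step of no change at the digits printed from compound 2 to compound 3 (within the scatter).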

Compound 3, inhibition constant: 71 nM
Estimate against measurement, compound 3: 56-fold (1.75 log units) above; the whole stated range lies above it.
By their numbers in this assay, from the lowest: compound 3; then compounds 1 and 2 (each within the scatter of the next).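

In this assay the change of the group on the carbonyl carbon to 1-(4-chloro-3-methylbenzyl)ethyl gives a 56-fold lower number from compound 2 to compound 3 (1.75 log units; beyond the scatter) and a 35-fold lower number from compound 1 to compound 3 (1.55 log units; beyond the scatter) and so, unlike the change of ring substituents alone, goes beyond the scatter. This place therefore responds strongly to replacing the whole group, a change that also removes the oxygen, which the earlier pair could not show. Nothing available explains this gain. Since the oxygen, the ring substituents and the chain all change together, the shown compounds do not reveal which of them carries the step. From the compounds shown here alone, what an amine or a longer chain on this carbonyl carbon would give also stays open.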